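Swapping One Aryl Group on a Compound Without a Number

A few compounds are considered here, and "the series" means these few. Any claim that something is new, unique, unknown or untested is made for them only; others in the source may bear on it.

Measured compounds:
compound 1 `COc1ccccc1/C=c1\c(=O)[nH]/c(=C/c2cccc(Cl)c2Cl)c(=O)n1C`: 200 nM
compound 2 `COc1ccccc1/C=c1\c(=O)[nH]/c(=C/c2ccccc2Cl)c(=O)n1C`: 200 nM
compound 3 `C=CCn1c(=O)/c(=C\c2ccc(F)c(Br)c2)[nH]c(=O)/c1=C\c1ccccc1OC`: "not active" (no number reported)

In a functional assay on HL-60 cells (Homo sapiens) for cytotoxicity, read by CCK-8 assay, with a stated time of 72 h (a higher number here means a weaker inhibitor, a lower number a stronger inhibitor), compound 1 gives 200 nM and compound 2 gives 200 nM. Among the compounds with values here, the only measured step, no change at the digits printed from compound 1 to compound 2 (within the scatter), is a hydrogen in place of chloro on an aromatic carbon. Compound 3 stands apart: in this assay compound 3 is reported "not active" (no number reported), so no single number exists for it. Compound 4 `C=CCn1c(=O)/c(=C\c2ccccc2C(F)(F)F)[nH]c(=O)/c1=C\c1ccccc1OC` differs from compound 3 by the change (2-(trifluoromethyl)phenyl in place of 3-bromo-4-fluorophenyl on a double-bonded chain carbon bound to an aromatic carbon). The measured step from compound 1 to compound 2 concerns a different change in different compounds, so it does not bear on this one, and no size or direction of step can be taken from the data. Compound 4 is therefore estimated only loosely at 3000 nM, within 300 nM to 30000 nM, with a real chance that the assay again reports no number.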

Compound 4, half-maximal inhibitory concentration: 4600 nM
Beside the measured number, compound 4's estimate is 1.5-fold (0.19 log units) below it; the measured number falls inside the stated range.
By their numbers in this assay, from the lowest: compounds 1 and 2 (each within the scatter of the next); then compound 4.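

Within the data shown here, compound 3 has no number, so no step to compound 4, at [ 4600 nM ], can be read. No measurement on hand offers an explanation for this result. The compounds shown leave open how large a change the swap to 2-(trifluoromethyl)phenyl brings.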